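The compounds below may be only part of what the source reports. "The series", "measured", "known", "first", "only" and "open" are said of these compounds alone.

Of the compounds shown here, three built on one shared core have been tested in a functional assay on isolated protein for agonist activity at Glucose-dependent insulinotropic receptor (Homo sapiens), read by HTRF and cAMP accumulation; on this read-out lower numbers stand for an effect already at smaller amounts and higher numbers for an effect only at larger amounts of compound. Compound 1 `CC(C)OC(=O)N1CCC(O[C@H]2CC[C@H](Oc3cnc(S(C)(=O)=O)cn3)CC2)CC1` gives 13.7 nM. Compound 2 `CS(=O)(=O)c1cnc(O[C@H]2CC[C@H](OC3CCN(C(=O)C4(C(F)(F)F)CCCC4)CC3)CC2)cn1` gives 38.4 nM, and compound 3 `CS(=O)(=O)c1cnc(O[C@H]2CC[C@H](OC3CCN(C(=O)C4(C(F)(F)F)CC4)CC3)CC2)cn1` gives 107 nM. Compound 3 thus stands highest of the three: there is a 2.8-fold higher number from compound 2 to compound 3 (0.45 log units; beyond the scatter), and a 7.8-fold higher number from compound 1 to compound 3 (0.89 log units; beyond the scatter). Each of these steps alters only the group attached to the carbonyl carbon; the carbonyl itself stays.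

Compound 4 `CC(C)c1noc(CN2CCC(O[C@H]3CC[C@H](Oc4cnc(S(C)(=O)=O)cn4)CC3)CC2)n1` goes further: (3-isopropyl-1,2,4-oxadiazol-5-yl)methyl in place of (1-(trifluoromethyl)cyclopropyl)carbonyl on an amine nitrogen in a ring. Here the carbonyl leaves together with its group, so the ring nitrogen carries a different kind of attachment altogether. Among the compounds with values here, no measured step covers a change of this kind; a 2.8-fold higher number from compound 1 to compound 2 (0.45 log units; beyond the scatter) and the two other steps show only that what sits at this position shifts the number by modest amounts. A step of uncertain direction is therefore expected, a 2.7-fold lower number from compound 3 to compound 4 (0.43 log units; beyond the scatter), with wide room on either side. Compound 4 is estimated at 40 nM, within a range from 6 nM to 300 nM.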

Compound 4, half-maximal effective concentration: 14 nM
Compound 4: the middle estimate sits 2.9-fold (0.46 log units) above what was measured, and the stated range covers the measured number.
By their numbers in this assay, from the lowest: compounds 1 and 4 (each within the scatter of the next); then compound 2; then compound 3.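

In this assay the ring nitrogen keeps a low number without any carbonyl on it: with (3-isopropyl-1,2,4-oxadiazol-5-yl)methyl in place of the amide groups there is a 7.6-fold lower number from compound 3 to compound 4 (0.88 log units; beyond the scatter) and also a 2.7-fold lower number from compound 2 to compound 4 (0.44 log units; beyond the scatter). Set against isopropoxycarbonyl, the same group gives a 1.0-fold higher number from compound 1 to compound 4 (0.01 log units; within the scatter) so a carbamate and a five-membered aromatic ring with 3 hetero atoms cannot be told apart at this position, and the carbonyl shared by compounds 1, 2 and 3 is shown not to be required by compound 4. Nothing measured here speaks to the reason for this result.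

Still open, as far as these compounds go, is which part of the new group counts: the oxadiazole ring, its isopropyl or the methyl link. A benzyl group on the ring nitrogen, or a tert-butyl in place of that isopropyl, would help to separate these parts.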